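The source may report more compounds than this note shows. Statements on the series, on what has been measured and on what is new or still open speak of the compounds shown alone.

Measured so far:
compound 1 `CCn1c(C(=O)NCCC(=O)OC)ccc1C(CC)(CC)c1ccc(OCS(=O)(=O)c2ccccc2)c(C)c1` — 40400 nM
compound 2 `CCn1c(C(=O)NCCN)ccc1C(CC)(CC)c1ccc(OCS(=O)(=O)c2ccccc2)c(C)c1` — 6890 nM

In a functional assay on PC-3 cells (Homo sapiens) for antiproliferative activity, read by MTT assay, with a stated time of 24 h (on this read-out lower numbers stand for stronger inhibition and higher numbers for weaker inhibition), compound 1 gives the highest of the two numbers; its nearest neighbour is compound 2, reached by a 5.9-fold lower number from compound 1 to compound 2 (0.77 log units; beyond the scatter), a step called modest.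

Compound 3 `CCn1c(C(=O)N[C@H](C)C(=O)O)ccc1C(CC)(CC)c1ccc(OCS(=O)(=O)c2ccccc2)c(C)c1` has not yet been measured. It differs from compound 1 by 1-carboxyethyl in place of 2-(methoxycarbonyl)ethyl on an amide-type nitrogen. For the measured compounds named here, the change made, like the one from compound 1 to compound 2, alters the end of the chain that hangs from the amide-type nitrogen, and it also shortens that chain by one heavy atom, so the earlier step is the only guide and an imperfect one.

That single step moved the number down by a clear margin, showing that this part of the structure can shift the read-out beyond the scatter. An acid is not an amine, and the data do not say whether the two behave alike. A downward step is expected for compound 3, smaller than the one seen, and uncertain in either direction: a 1.6-fold lower number from compound 1 to compound 3 (0.21 log units; within the scatter). Compound 3 is therefore estimated at 25000 nM, within 8000 nM to 80000 nM.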

Compound 3, half-maximal inhibitory concentration: 20100 nM
Compound 3: the middle estimate sits 1.2-fold (0.09 log units) above what was measured, within the range that was stated.
By their numbers in this assay, from the lowest: compound 2; then compounds 3 and 1 (each within the scatter of the next).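

In this assay, putting 1-carboxyethyl in place of 2-(methoxycarbonyl)ethyl on the amide-type nitrogen gives a 2.0-fold lower number from compound 1 to compound 3 (0.30 log units; within the scatter), so compound 1 and compound 3 cannot be told apart here, even though the swap replaces the ester with a carboxylic acid and adds a defined stereocentre. Putting 1-carboxyethyl in place of 2-aminoethyl at the same place gives a 2.9-fold higher number from compound 2 to compound 3 (0.46 log units; beyond the scatter), which shows that compound 2, the amine, stands apart from both compound 1 and compound 3, while the ester and the acid do not stand apart from each other. Nothing measured alongside these numbers speaks to the reason for this pattern.

The change from compound 1 to compound 3 alters the end group, the way the chain is attached and the stereochemistry all at once, so the compounds shown cannot assign any share of the result to one of these features. As far as these compounds go, a 2-carboxyethyl group would pair the acid with the chain of compound 1, and a 1-aminoethyl group would pair the amine with the chain of compound 3, so how each of these would read remains open.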